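The source may report more compounds than this note shows. Statements on the series, on what has been measured and on what is new or still open speak of the compounds shown alone.

Compound 1 `OCCOCn1cnc2c(O)ncnc21`: in a functional assay on L1210 cells (Mus musculus) for inhibition (a higher number here means a weaker inhibitor, a lower number a stronger inhibitor), compound 1 gives only a limit, > 1000 ug/mL.
Compound 2 `Nc1nc(Cl)c2ncn(COCCO)c2n1`: in this assay compound 2 likewise gives only a limit, > 1000 ug/mL.
Compound 3 `CC(=O)OCCOCn1cnc2c(Cl)ncnc21`: in this assay compound 3 gives 475 ug/mL.

Compound 3 is the only one of the three with a measured number; the other two values sit at the limit of > 1000 ug/mL in this assay, at which 2 of the 3 values shown sit, so compound 3 can be placed only against that limit and not ranked against the others. The compound to be measured is compound 4 `CC(=O)OCCOCn1cnc2c(Cl)nc(N)nc21`. It differs from compound 3 by amino in place of hydrogen on an aromatic carbon. For the measured compounds named here, no measured pair in this set differs in one place, so the size of this step has no direct precedent. Compound 2, which carries the same amino group next to the chloro group but without the acetyl ester, gives only a limit in this assay, and that is the nearest indication available. Compound 4 is therefore expected to be a weaker inhibitor than compound 3, with a step of a 1.9-fold higher number from compound 3 to compound 4 (0.28 log units; within the scatter) expected in this assay. The estimate for compound 4 in this assay is 900 ug/mL, within a range from 350 ug/mL to 2500 ug/mL, with a fair chance that only a limit is reported.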

Compound 4, concentration for 50% inhibition: > 1000 ug/mL
Compound 4 was reported as a limit; the forecaster's own chance of this, stated with the estimate: 50%; middle value at least 1.1-fold (0.04 log units) away from the limit.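

In this assay, for the compounds shown here, amino in place of hydrogen on an aromatic carbon, between two ring nitrogen atoms, gives the first readable step of the set: an at least 2.1-fold higher number from compound 3 to compound 4 (0.32 log units; beyond the scatter). The value of compound 4 is a limit and not a number, so this size is only a lower bound and the true loss of inhibition cannot be told. The step between compound 2 and compound 4, acetyl in place of hydrogen on an oxygen, cannot be read, and the set now gathers at one ceiling: the limit of > 1000 ug/mL in this assay, at which 3 of the 4 values shown sit.

Going by these compounds, whether a methyl or a methylamino group on this aromatic carbon would keep inhibition closer to that of compound 3 remains open. Also open, on these data alone, is how much the acetyl ester contributes to the value of compound 3, as no readable step ties it to a free alcohol.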